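The source may hold more compounds than are shown below. What is called first, only, known or untested is meant among the compounds shown, and "the series" means these compounds.

Compound 1 `CCCCCCCCOc1nc(N)nc2c1ncn2/C=C1/CC1(CO)CO` in an ADME assay on HFF cells (Homo sapiens) for cytotoxicity, with a stated time of 8 days (a lower number here means that less compound is tolerated, a higher number that more compound is tolerated), gives > 300000 nM, a limit.
Compound 2 `Nc1nc(NC2CC2)c2ncn(/C=C3/CC3(CO)CO)c2n1` gives > 300000 nM, a limit.
Compound 3 `CCCCNc1nc(N)nc2c1ncn2/C=C1/CC1(CO)CO` gives > 300000 nM, a limit.

Going by the values given here, compound 2 thus stands only at a limit in this assay, as do the other two; the limit of > 300000 nM in this assay, at which 3 of the 3 values shown sit, is the whole record for the series so far. Compound 4 `Nc1nc(N2CCCC2)c2ncn(/C=C3/CC3(CO)CO)c2n1` differs from compound 2 by pyrrolidin-1-yl in place of cyclopropylamino on an aromatic carbon. The steps that touch compound 2 are a step that the two limits leave unreadable from compound 1 to compound 2 and a step that the two limits leave unreadable from compound 2 to compound 3; neither can be sized, so no direction can be read from them. The step to compound 4 is expected to be a number no higher from compound 2 to compound 4 (the limit leaves the size open), most likely ending again at the limit. Compound 4 is estimated at 300000 nM, with a range from 80000 nM to 1000000 nM in this assay.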

Compound 4, half-maximal cytotoxic concentration: > 300000 nM
Compound 4 gave a limit, no number (the forecaster's own chance of this, stated with the estimate: 75%); the middle value lies on the limit itself.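

In this assay, the steps linking compound 4 to compound 1, compound 2 and compound 3 cannot be read, as all four values are limits: the limit of > 300000 nM in this assay, at which 4 of the 4 values shown sit.

The compounds shown leave open whether these groups on the aromatic carbon differ at all in tolerated concentration.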